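The source may hold more compounds than are shown below. What is called first, only, known or untested is meant among the compounds shown, and "the series" means these compounds.

Measured compounds:
compound 1, `Cc1ccc(C2CN(S(=O)(=O)c3ccc4c(c3)CCC4)C(=O)N2)cc1`: 72500 nM
compound 2, `O=C1NC(c2ccccc2)CN1S(=O)(=O)c1ccccc1`: 116000 nM

In a functional assay on SK-MEL-2 cells (Homo sapiens) for cytotoxicity (on this read-out higher numbers stand for weaker inhibition and lower numbers for stronger inhibition), compound 1 gives 72500 nM, and compound 2 gives 116000 nM; the two numbers lie within the scatter of each other, so neither stands apart. Compound 3, `O=C1NC(c2ccc(Cl)cc2)CN1S(=O)(=O)c1ccc2c(c1)CCC2`, has not been measured in this assay. It differs from compound 1 in one place: chloro in place of methyl on an aromatic carbon. Going by the values given here, no comparable step between measured compounds is available, so the size of the effect is unknown. Compound 3 is expected to give 70000 nM, between 30000 nM and 170000 nM, a step of a 1.0-fold lower number from compound 1 to compound 3 (0.02 log units; within the scatter) that is estimated to stay within the scatter.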

Compound 3, half-maximal inhibitory concentration: 64300 nM
Compound 3: middle estimate off by 1.1-fold (0.04 log units), on the high side; the range from low to high includes it.
By their numbers in this assay, from the lowest: compounds 3, 1 and 2 (each within the scatter of the next).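

Changing the 4-methylphenyl to a 4-chlorophenyl gives a 1.1-fold lower number from compound 1 to compound 3 (0.05 log units; within the scatter) in this assay. Going by these compounds alone, this is the first single-place comparison, and at this aromatic carbon, para to a large group, chloro and methyl cannot be told apart on this read-out. Nothing measured here addresses why the two groups read alike.

On these data alone, it remains open whether an amine or a carboxylic acid at this position would shift the number beyond the scatter. Also open, as far as these compounds go, is whether any single change elsewhere on the core of compound 1 would do so.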